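The source may hold more compounds than are shown below. What is called first, only, known or untested is meant among the compounds shown, and "the series" means these compounds.

The series rests on the acylguanidine scaffold carried by compound 1 `CCSc1cc(C)c(C(=O)N=C(N)N)cc1S(C)(=O)=O` and compound 2 `Cc1cc(Sc2ccccc2)c(S(C)(=O)=O)cc1C(=O)N=C(N)N`, which differ only on a sulfur. For the measured compounds named here, in a functional assay for inhibition of sodium/hydrogen exchanger (Oryctolagus cuniculus) (on this read-out lower numbers stand for stronger inhibition and higher numbers for weaker inhibition), compound 1 gives 5.9 nM, while compound 2 gives 14 nM; the step of a 2.4-fold higher number from compound 1 to compound 2 (0.38 log units; beyond the scatter) is modest but beyond the scatter, so compound 2 holds the higher of the two numbers recorded so far, with compound 1 as its only neighbour.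

Compound 3 `Cc1cc(O)c(S(C)(=O)=O)cc1C(=O)N=C(N)N` is the next member, not yet measured. Relative to compound 2 the change is hydroxy in place of phenylsulfanyl on an aromatic carbon, ortho to a methylsulfonyl group, meta to a methyl group and para to the acylguanidine side.

Going by the values given here, the only measured step that touches this position is the one from compound 1 to compound 2, where a phenyl replaced an ethyl on the sulfur and the number rose modestly. That step says nothing about removing the sulfur altogether and placing a single oxygen atom there, so the direction of the step into compound 3 in this assay is not anchored by data. A moderate rise in the number is nevertheless expected for compound 3, reaching 40 nM with a range of 8 nM to 200 nM, which corresponds to an expected step of a 2.9-fold higher number from compound 2 to compound 3 (0.46 log units; beyond the scatter).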

Compound 3, half-maximal inhibitory concentration: 220 nM
Compound 3: the middle estimate sits 5.5-fold (0.74 log units) below what was measured; measured number above the stated range.
By their numbers in this assay, from the lowest: compound 1; then compound 2; then compound 3.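

In this assay the exchange on the sulfur had moved the number only modestly, with a 2.4-fold higher number from compound 1 to compound 2 (0.38 log units; beyond the scatter), but replacing the whole sulfur-linked group is a far larger change: hydroxy in place of phenylsulfanyl gives a 16-fold higher number from compound 2 to compound 3 (1.20 log units; beyond the scatter), and hydroxy in place of ethylsulfanyl gives a 37-fold higher number from compound 1 to compound 3 (1.57 log units; beyond the scatter). The position, on an aromatic carbon ortho to a methylsulfonyl group and para to a group of 6 heavy atoms, is therefore far from indifferent to what it carries, and among these three compounds both sulfur-linked groups give lower numbers than hydroxy, with no compound going against that order. No measurement at hand explains why the step to hydroxy is so large.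

The compounds shown do not separate the loss of the sulfur from the loss of the ethyl or phenyl group attached to it, a question that a methoxy or phenoxy group at this position would address directly. They also leave open how an amine, a chlorine or a longer chain on the sulfur, such as butyl, would fall relative to the ethylsulfanyl of compound 1 and the hydroxy of compound 3.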